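A Nitro Group Replaces Chlorine on Compound 3's Sulfonyl

This account rests on a few compounds, and the source may have more. Where it says the series, first, only, none or still open, it means among the compounds named here.

Of the compounds shown here, three sharing one core have been measured in an assay on isolated protein with dual specificity calcium/calmodulin-dependent 3',5'-cyclic nucleotide phosphodiesterase 1B (Bos taurus) as the target, tested at 100 uM; on this read-out higher numbers stand for more inhibition at the one concentration tested (going by the name of the read-out) and lower numbers for less inhibition. Compound 1 `Nc1nc2c(c(=O)n(CC3CC3)c(=O)n2CC2CC2)n1Cc1ccccc1` gives 27%, and compound 2 `Nc1nc2c(c(=O)n(CC3CC3)c(=O)n2CC2CC2)n1Cc1ccc([N+](=O)[O-])cc1`, which carries a nitro group on its benzyl ring, gives 30%; the change of a number 3 percentage points higher from compound 1 to compound 2 (within the scatter) is too small to count. Compound 3 `Nc1nc2c(c(=O)n(CC3CC3)c(=O)n2CC2CC2)n1S(=O)(=O)c1ccc(Cl)cc1` stands lowest of the three, at 1%, and the drops of a number 26 percentage points lower from compound 1 to compound 3 (beyond the scatter) and a number 29 percentage points lower from compound 2 to compound 3 (beyond the scatter) are real, though modest.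

Compound 4 `Nc1nc2c(c(=O)n(CC3CC3)c(=O)n2CC2CC2)n1S(=O)(=O)c1ccc([N+](=O)[O-])cc1` keeps the sulfonyl of compound 3 and differs from it only as follows: nitro in place of chloro on an aromatic carbon. For the measured compounds named here, no measured step exchanges chloro for nitro, so the closest guide is the step from compound 1 to compound 2, where a nitro group entered a benzyl ring and this assay barely moved. The sulfonyl that pulled compound 3 down remains in place.

Compound 4 is therefore expected to stay near the floor, and the expected step of a number 3 percentage points higher from compound 3 to compound 4 (within the scatter) lies within the scatter. In this assay compound 4 is estimated at 4%, with a likely range from 0% to 15%.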

Compound 4, a percentage reported as inhibition, at one concentration (the size of the read-out at that concentration, not a potency): 14%
Beside the measured number, compound 4's estimate is 10 percentage points below it, within the range that was stated.
By their numbers in this assay, from the lowest: compound 3; then compound 4; then compounds 1 and 2 (each within the scatter of the next).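

The ring carried on the sulfonyl is not a silent part of these molecules: in this assay the exchange of chloro for nitro, on the aromatic carbon para to a large group, gives a number 13 percentage points higher from compound 3 to compound 4 (beyond the scatter) and is large enough to count. For the compounds shown here, the earlier compounds showed a nitro group entering the benzyl ring with a number 3 percentage points higher from compound 1 to compound 2 (within the scatter) and showed the sulfonyl only as a loss, so this is the first sign that a nitro group can register on this read-out and that the sulfonyl alone does not pin the number near zero. Nothing available here explains the rise.

The exchange replaces one heavy atom with three and adds two hydrogen-bond acceptors at once, so this single pair cannot separate the heavy-atom count from the acceptors. Going by these compounds, an amine or a carboxylic acid at the same place on the sulfonyl ring would show whether the rise is particular to nitro, and how chloro would read on the benzyl ring also stays open.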